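Cyclopropyl for phenyl on the ring amide nitrogen

A few compounds are considered here, and "the series" means these few. Any claim that something is new, unique, unknown or untested is made for them only; others in the source may bear on it.

Compound 1 `O=C1COc2ccc(-c3cccc(NS(=O)(=O)c4ccc(F)cc4)c3)cc2N1`: 20100 nM
Compound 2 `O=C1COc2ccc(-c3cccc(NS(=O)(=O)c4ccc(F)cc4)c3)cc2N1c1ccc(Cl)cc1`: 32500 nM
Compound 3 `O=C1COc2ccc(-c3cccc(NS(=O)(=O)c4ccc(F)cc4)c3)cc2N1c1ccccc1`: > 40000 nM

All three compounds were tested in a functional assay on A-375 cells (Homo sapiens) for antiproliferative activity, read by MTT assay, with a stated time of 72 h; on this read-out higher numbers stand for weaker inhibition and lower numbers for stronger inhibition. Compound 3 has no number, only (the limit of > 40000 nM in this assay, at which 1 of the 3 values shown sits). Its true position on the scale is therefore open.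

Compound 4 `O=C1COc2ccc(-c3cccc(NS(=O)(=O)c4ccc(F)cc4)c3)cc2N1C1CC1` carries cyclopropyl in place of phenyl on an amide-type nitrogen in a ring, with the rest of the structure unchanged: cyclopropyl in place of phenyl on an amide-type nitrogen in a ring.

Among the compounds with values here, three measured steps touch this same nitrogen or its substituent. Putting a ring group on the nitrogen gave a 1.6-fold higher number from compound 1 to compound 2 (0.21 log units; within the scatter) and an at least 1.9-fold higher number from compound 1 to compound 3 (0.29 log units; that floor lies within the scatter). Removing the chloro group gave an at least 1.2-fold higher number from compound 2 to compound 3 (0.09 log units; that floor lies within the scatter). None of these is shown to go beyond the scatter, although the two steps that end at compound 3 are only floors. Cyclopropyl itself has not been tested on this nitrogen in these compounds.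

The numbers nearest to the change are those of compound 1 at 20100 nM and compound 2 at 32500 nM, so compound 4 is expected to fall in the same region. The expected change is an at least 1.3-fold lower number from compound 3 to compound 4 (0.12 log units; that floor lies within the scatter), and no step beyond the scatter is anticipated. For compound 4 the estimated value is 30000 nM, with an expected range of 15000 nM to 55000 nM.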

Compound 4, half-maximal inhibitory concentration: > 40000 nM
Compound 4: a limit, no number; the forecaster's own chance of this, stated with the estimate: 35%; middle value at least 1.3-fold (0.12 log units) away from the limit.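

In this assay compound 4, with cyclopropyl on the amide-type nitrogen in a ring, gives a limit and not a number, as compound 3 does, so the step between these two cannot be read and the two cannot be ranked: the limit of > 40000 nM in this assay, at which 2 of the 4 values shown sit.

The steps that can be read are only floors, an at least 1.2-fold higher number from compound 2 to compound 4 (0.09 log units; that floor lies within the scatter) and an at least 1.9-fold higher number from compound 1 to compound 4 (0.29 log units; that floor lies within the scatter), so cyclopropyl, like phenyl, is not shown to move the result beyond the scatter. The new point is that swapping the phenyl for a three-membered non-aromatic ring of carbon only still gives no number, and of the three compounds with a ring group on this nitrogen, only compound 2 has one, 32500 nM.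

As far as these compounds go, how far compound 3 and compound 4 lie past the limit stays open, and with it whether either truly differs from compound 1. Also open, from the compounds shown here alone, is whether a methyl group, a longer chain such as propyl or a chain ending in an amine on this nitrogen would give a readable number, and whether any group there would differ from compound 1 by more than the scatter.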